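The source may report more compounds than this note shows. Statements on the series, on what has been measured and on what is new or still open speak of the compounds shown alone.

Measured so far in a functional assay on MCF7 cells (Homo sapiens) for antiproliferative activity, read by MTT assay, with a stated time of 72 h; on this read-out lower numbers stand for stronger inhibition and higher numbers for weaker inhibition:
- compound 1 `COc1cc(/C=C/c2ccc(C3=C(c4ccc(O)cc4)C4CC(S(=O)(=O)Oc5ccccc5)C3O4)cc2)cc(OC)c1`: > 100000 nM (a limit of the assay)
- compound 2 `COc1cc(/C=C/c2ccc(C3=C(c4ccc(O)cc4)C4CC(S(=O)(=O)Oc5cccc(OC)c5)C3O4)cc2)cc(OC)c1`: 77100 nM
- compound 3 `O=S(=O)(Oc1cccc(C(F)(F)F)c1)C1CC2OC1C(c1ccc(/C=C/c3cc(O)cc(O)c3)cc1)=C2c1ccc(O)cc1`: 11500 nM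

Of the two actual numbers, compound 3 holds the lower at 11500 nM, while compound 2 shows 77100 nM. The entry for compound 1 is only a limit.

Compound 4 `O=S(=O)(Oc1cccc2ccccc12)C1CC2OC1C(c1ccc(/C=C/c3cc(O)cc(O)c3)cc1)=C2c1ccc(O)cc1` keeps everything in compound 3 except one group: naphthalen-1-yl in place of 3-(trifluoromethyl)phenyl on an oxygen. In words, naphthalen-1-yl stands in place of 3-(trifluoromethyl)phenyl on an oxygen whose other neighbour is the sulfonyl sulfur.

For the measured compounds named here, only one measured step changes a single place in this group: an at least 1.2-fold lower number from compound 1 to compound 2 (0.11 log units; that floor lies within the scatter). It starts from a limit and swaps a different substituent, so it gives no measured size for the exchange made here. Going by the values given here, with no step pointing either way, no shift beyond the scatter is expected in this assay. The estimated change is a 1.3-fold higher number from compound 3 to compound 4 (0.12 log units; within the scatter). For compound 4 the expected value is 15000 nM, with an estimated range of 4500 nM to 50000 nM.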

Compound 4, half-maximal inhibitory concentration: 11000 nM
Estimate against measurement, compound 4: 1.4-fold (0.13 log units) above; measured number inside the range.
By their numbers in this assay, from the lowest: compounds 4 and 3 (each within the scatter of the next); then compound 2. At a limit, above all of these: compound 1.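

The exchange on the oxygen whose other neighbour is the sulfonyl sulfur gives a 1.0-fold lower number from compound 3 to compound 4 (0.02 log units; within the scatter) in this assay. For the compounds shown here, this is the first step at this position joining two actual numbers, and it shows that naphthalen-1-yl, with 2 six-membered aromatic rings of carbon only, and 3-(trifluoromethyl)phenyl, with one, cannot be told apart in this read-out, although both groups hold 10 heavy atoms and only one contains fluorine. Compound 1 stands at a limit, so the earlier step on this aromatic group gives only a floor: the limit of > 100000 nM in this assay, at which 1 of the 4 values shown sits.

Compounds 1 and 2 differ from compounds 3 and 4 in more than one place, so no single group can be held to account for the gap between them. From the compounds shown here alone, whether an amine or a carboxylic acid on this aromatic group, or a longer chain in its place, would move the number remains open.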